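The source may report more compounds than this note shows. Statements on the series, on what has been measured and on what is new or still open speak of the compounds shown alone.

Working notes on the series. Compound 1 `CC1(C)S[C@@H]2/C(=C\C(=O)c3ccco3)C(=O)N2[C@H]1C(=O)OC(c1ccccc1)c1ccccc1` is assessed in a functional assay on OE19 cells (Homo sapiens) for cytotoxicity, read by MTT assay, with a stated time of 48 h (a higher number here means a weaker inhibitor, a lower number a stronger inhibitor), where compound 1 gives 54300 nM. Two further members of the set have been run in this assay: compound 2 `CC1(C)[C@H](C(=O)OC(c2ccccc2)c2ccccc2)N2C(=O)/C(=C/C(=O)c3ccc([N+](=O)[O-])cc3)[C@H]2S1(=O)=O` gives 95500 nM, and compound 3 `COC(=O)/C=C1\C[C@H]2SC(C)(C)[C@H](C(=O)OC(c3ccccc3)c3ccccc3)N2C1=O` gives 99700 nM. All three numbers sit within the usual scatter of one another, so compound 1 cannot be set apart from compound 2 or compound 3 on these values; the set as a whole reads as weak in this assay.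

Compound 4 `CC1(C)S[C@@H]2/C(=C\C(=O)OCc3ccccc3)C(=O)N2[C@H]1C(=O)OC(c1ccccc1)c1ccccc1` has not been measured. Relative to compound 1 the change is benzyloxy in place of furan-2-yl on a carbonyl carbon. Among the measured compounds shown here, no measured pair in the set isolates this change, so no step of this kind is known here. Compound 3 carries an ester at the exocyclic alkene and gives 99700 nM, close to compound 1, which offers the only anchor. The step from compound 1 to compound 4 is therefore expected to be small, a 1.3-fold higher number from compound 1 to compound 4 (0.11 log units; within the scatter), with no direction beyond the scatter. Compound 4 is estimated at 70000 nM in this assay, with a range from 25000 nM to 200000 nM.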

Compound 4, half-maximal inhibitory concentration: 8200 nM
The estimate for compound 4 lay 8.5-fold (0.93 log units) above the measured number; the measured number lies below the stated range.
By their numbers in this assay, from the lowest: compound 4; then compounds 1, 2 and 3 (each within the scatter of the next).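

In this assay, the carbonyl carbon on the double-bonded chain carbon turns out to be a place where a single change can be read: benzyloxy in place of furan-2-yl gives a 6.6-fold lower number from compound 1 to compound 4 (0.82 log units; beyond the scatter), a modest step but one beyond the scatter. The earlier compounds shown here could not show this, as they offered no pair differing in one place and their values could not be told apart. No measurement here bears on the origin of the step.

One step cannot separate the loss of furan-2-yl from the entry of benzyloxy, and it gives no trend across groups at this position. A benzylamino group, a carboxylic acid or a longer chain ending in a phenyl ring on the same carbonyl carbon would show how far the step depends on the oxygen link and on the reach of the aromatic ring.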